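A few compounds are considered here, and "the series" means these few. Any claim that something is new, unique, unknown or untested is made for them only; others in the source may bear on it.

Working notes on the series. Two analogues of the shared core have been run in a functional assay on KBVIN cells (Homo sapiens) for antiproliferative activity, read by sulforhodamine B assay, with a stated time of 3 days (on this read-out lower numbers stand for an effect already at smaller amounts and higher numbers for an effect only at larger amounts of compound), so far. Compound 1 `CCCc1ccc(-c2cc(=O)c3c(o2)C(CC)(CC)C(=O)C(CC)=C3O)cc1` carries a propyl group on the phenyl ring, and in this assay compound 1 gives 12.2 uM. Compound 2 `CCOc1ccc(-c2cc(=O)c3c(o2)C(CC)(CC)C(=O)C(CC)=C3O)cc1` differs in one place, ethoxy in place of propyl on an aromatic carbon, and in this assay compound 2 gives 7.54 uM. The one measured step, a 1.6-fold lower number from compound 1 to compound 2 (0.21 log units; within the scatter), is within the scatter, so on the numbers shown compound 2 holds the lowest of two values, with compound 1 the nearest and not separated from it beyond the scatter.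

The next analogue, compound 3 `CCC1=C(O)c2c(oc(-c3ccc(COC)cc3)cc2=O)C(CC)(CC)C1=O`, is related to compound 2 by methoxymethyl in place of ethoxy on an aromatic carbon; the two have the same atoms, joined differently. Within the data shown here, the only step that bears on it is the exchange of the group at this position from compound 1 to compound 2, which was within the scatter. No step beyond the scatter is therefore expected here, in either direction. For compound 3 the value in this assay is estimated at 9 uM, in the range 4 uM to 20 uM; this expectation corresponds to a step of a 1.2-fold higher number from compound 2 to compound 3 (0.08 log units; within the scatter).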

Compound 3, concentration for half-maximal effect: 3.4 uM
Estimate against measurement, compound 3: 2.6-fold (0.42 log units) above, outside the stated range (below it).
By their numbers in this assay, from the lowest: compound 3; then compounds 2 and 1 (each within the scatter of the next).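

At this position, on an aromatic carbon para to a large group, the exchange of one group for another now moves the number beyond the scatter: in this assay, methoxymethyl in place of ethoxy gives a 2.2-fold lower number from compound 2 to compound 3 (0.35 log units; beyond the scatter), although the two groups have the same heavy-atom count and the two compounds the same atoms, joined differently. Compound 1 and compound 2 did not separate beyond the scatter, whereas methoxy in place of ethyl on a saturated chain carbon bound to an aromatic carbon gives a 3.6-fold lower number from compound 1 to compound 3 (0.55 log units; beyond the scatter), so among these three compounds the arrangement of the group, and not only its size, goes with a modest difference in the number. Nothing at hand gives a reason for this difference.

Three compounds cannot show whether the lower number follows the oxygen one carbon out from the aromatic carbon or is specific to methoxymethyl itself. Going by these compounds, a longer chain such as ethoxymethyl, an alcohol such as hydroxymethyl, or an amine such as dimethylaminomethyl at this place would each bear on that question, and the shape of the trend remains open.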